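From Difluorophenyl to Trifluoromethylphenyl on One Measured Value

This account rests on a few compounds, and the source may have more. Where it says the series, first, only, none or still open, it means among the compounds named here.

Measured so far in a functional assay on a cell-free system (Platelet, plasma, Homo sapiens) for inhibition; a lower number here means a stronger inhibitor, a higher number a weaker inhibitor

Compound 1 `O=C(Nc1cccc(OCc2ccc(-c3cc(F)ccc3F)cc2)c1)C1CCNCC1` gives "not determined" (no result reported)
Compound 2 `O=C(Nc1cccc(OCc2ccc(-c3c(F)cccc3F)cc2)c1)C1CCNCC1` gives "not determined" (no result reported)
Compound 3 `O=C(Nc1cccc(OCc2ccc(-c3cc(F)cc(F)c3)cc2)c1)C1CCNCC1` gives 27800 nM

Only one of these three entries is a number. Compound 3 (27800 nM) therefore cannot be ranked against compound 1 or compound 2. Neither of these two has a result to compare. Among the compounds with values here, with a single value, there is also no measured step showing how much a change in this part of the molecule matters.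

Compound 4 `O=C(Nc1cccc(OCc2ccc(-c3ccc(C(F)(F)F)cc3)cc2)c1)C1CCNCC1` keeps the shared core but has 4-(trifluoromethyl)phenyl in place of 3,5-difluorophenyl on an aromatic carbon, para to a large group. Within the data shown here, the counted difference is 4-(trifluoromethyl)phenyl in place of 3,5-difluorophenyl on an aromatic carbon and it is the only structural change between the two compounds.

The sole anchor for a prediction is compound 3 (27800 nM), so the forecast stays close to that value, and the range is kept wide. In this assay no step beyond the usual scatter is expected, and no direction can be favoured with confidence. The estimated step (a 1.1-fold lower number from compound 3 to compound 4 (0.05 log units; within the scatter)) is accordingly small. For compound 4 the expected value is 25000 nM within an estimated range from 8000 nM to 70000 nM as the likely span.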

Compound 4, half-maximal inhibitory concentration: 65700 nM
The estimate for compound 4 lay 2.6-fold (0.42 log units) below the measured number; the range from low to high includes it.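

In this assay, putting 4-(trifluoromethyl)phenyl in place of 3,5-difluorophenyl, on an aromatic carbon para to a large group, gives a 2.4-fold higher number from compound 3 to compound 4 (0.37 log units; beyond the scatter). Within the data shown here, this is the first measured evidence that the group at this position affects the read-out: the step is modest, but it runs towards weaker inhibition and lies beyond the usual scatter. Neither group carries a hydrogen-bond donor, a hydrogen-bond acceptor or a net charge, and no supporting measurement is available to explain the step, so its cause remains unassigned.

This single step cannot separate the effect of removing the two fluorines from that of adding the trifluoromethyl group or of changing where the ring is substituted, and steps involving compound 1 or compound 2 cannot be read because neither has a numerical result. As far as these compounds go, it also remains open whether a different group on this ring, such as an amine or a carboxylic acid, would give a lower number than either compound 3 or compound 4.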